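A Step Outward From the Aminomethyl Group

The compounds below may be only part of what the source reports. "The series", "measured", "known", "first", "only" and "open" are said of these compounds alone.

Compound 1 `COc1cc(Nc2nc(Cl)cc3c(C(C)C)n[nH]c23)cc(OC)c1OC`: 6.54
Compound 2 `COc1cc(Nc2nc(CN)cc3c(-c4ccccc4)n[nH]c23)cc(OC)c1OC`: 7.29

In an assay on CHO-K1 cells for binding affinity to adenosine receptor A1 (Homo sapiens), using Schild analysis, compound 2 gives the higher of the two values, and compound 1 gives a value that is lower by a gap beyond the scatter. Compound 3 `COc1cc(Nc2nc(CNCC3CCN(C)CC3)cc3c(-c4ccccc4)n[nH]c23)cc(OC)c1OC` carries the change (1-methylpiperidin-4-yl)methyl in place of hydrogen on an amine nitrogen on the aminomethyl group of compound 2. Within the data shown here, no measured pair shows such a step, so nothing in these two values tells how this growth alters the result. The step from compound 2 to compound 3 is expected to be a number 0.09 log units lower from compound 2 to compound 3 (within the scatter), that is, no shift beyond the scatter. Compound 3 is thus estimated at 7.2, within 6.6 to 7.8.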

Compound 3, acid dissociation constant: 6.5
Compound 3: middle estimate off by 0.70 log units, on the high side; the measured number lies below the stated range.
By their numbers in this assay, from the lowest: compounds 3 and 1 (each within the scatter of the next); then compound 2.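

In this assay, the amine nitrogen of the aminomethyl group proves sensitive to growth: (1-methylpiperidin-4-yl)methyl in place of hydrogen gives a number 0.79 log units lower from compound 2 to compound 3 (beyond the scatter). Among these compounds, this is the first measured step at this position, so the earlier values could not show that this substitution lowers the number beyond the scatter. Nothing at hand accounts for the drop. Going by these compounds, whether a small group on this nitrogen, such as methyl or acetyl, would lower the number as well remains open. So does the outcome for a 2-hydroxyethyl chain there.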